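Nitrooxy for methyl across two fluorobenzylidene piperidinone cores

The compounds below may be only part of what the source reports. "The series", "measured", "known", "first", "only" and "open" are said of these compounds alone.

Compound 1 `Cc1ccc(S(=O)(=O)N2C/C(=C\c3cccc(F)c3)C(=O)/C(=C/c3cccc(F)c3)C2)cc1`: 18100 nM
Compound 2 `O=C1/C(=C/c2cccc(F)c2)CN(S(=O)(=O)c2ccc(O[N+](=O)[O-])cc2)C/C1=C\c1cccc(F)c1`: 15300 nM
Compound 3 `Cc1ccc(S(=O)(=O)N2C/C(=C\c3ccc(F)cc3)C(=O)/C(=C/c3ccc(F)cc3)C2)cc1`: 5000 nM

In a functional assay on SMMC-7721 cells (Homo sapiens) for cytotoxicity, read by MTT assay, with a stated time of 24 h (a lower number here means a stronger inhibitor, a higher number a weaker inhibitor), compound 1 gives 18100 nM and compound 2 gives 15300 nM. The change between them is nitrooxy in place of methyl on an aromatic carbon and it made a step of a 1.2-fold lower number from compound 1 to compound 2 (0.07 log units; within the scatter). Compound 3 shares the same atoms as compound 1 but joined differently; the difference between the two cores is not broken down here. In this assay compound 3 gives 5000 nM, which stands beyond the scatter from both compound 1 and compound 2.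

Compound 4 `O=C1/C(=C/c2ccc(F)cc2)CN(S(=O)(=O)c2ccc(O[N+](=O)[O-])cc2)C/C1=C\c1ccc(F)cc1` has not yet been measured. It differs from compound 3 by nitrooxy in place of methyl on an aromatic carbon, the same change that carried compound 1 to compound 2, and it occurs twice among the compounds shown. On the strength of the earlier step of a 1.2-fold lower number from compound 1 to compound 2 (0.07 log units; within the scatter), a step of about the same size is expected, namely a 1.2-fold lower number from compound 3 to compound 4 (0.08 log units; within the scatter). Compound 4 is therefore estimated at 4200 nM, with a range from 2000 nM to 9000 nM in this assay.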

Compound 4, half-maximal inhibitory concentration: 5000 nM
Compound 4: the middle estimate sits 1.2-fold (0.08 log units) below what was measured; the measured number falls inside the stated range.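

In this assay, nitrooxy in place of methyl on the second core gives no change at the digits printed from compound 3 to compound 4 (within the scatter). Set beside the earlier step, the change carries from one core to the other with no difference that can be told apart from the scatter: the same change on two cores in this assay, a 1.2-fold lower number (0.07 log units; within the scatter) from compound 1 to compound 2 and no change at the digits printed (within the scatter) from compound 3 to compound 4, 1.2-fold (0.07 log units) apart, within the scatter of two such steps This shows that, in this one cell assay and at this one stated time, the swap leaves the number within the scatter on both cores; it does not show that the same would hold on any core beyond these two, and since neither step has a size beyond the scatter, the pair cannot show that a real effect carries over.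

The compounds shown leave open whether another group in the place of the methyl, such as an amine or a carboxylic acid, would move the number on either core. They also leave open whether nitrooxy would stay without effect on a core carrying methoxy in place of fluorine.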